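The source may hold more compounds than are shown below. What is called first, only, known or untested is meant among the compounds shown, and "the series" means these compounds.

Of the compounds shown here, three have so far been measured in an assay on membranes from HEK293 cells for displacement of a labelled ligand from adenosine receptor A2b (Homo sapiens), read by scintillation counting, with a stated time of 30 min, tested at 1 uM; on this read-out higher numbers stand for more inhibition at the one concentration tested (going by the name of the read-out) and lower numbers for less inhibition. Compound 1, `CCCOC(=O)C1=C(C)NC(=S)NC1c1ccoc1`, gives 45%. Compound 2, `CC1=C(C(=O)OCC(C)C)C(c2ccoc2)NC(=S)N1`, gives 1% in this assay. Compound 3, `CCOC(=O)C1=C(C)N(C)C(=O)NC1c1ccsc1`, gives 53% in this assay, and compound 4, `CCCOC(=O)C1=C(C)N(C)C(=O)NC1c1ccsc1`, has not yet been measured.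

The change from compound 1 to compound 2, (methyl in place of hydrogen on a saturated chain carbon bound to two saturated chain carbons), brought a number 44 percentage points lower from compound 1 to compound 2 (beyond the scatter). Compound 3 has the same atoms as compound 1 joined differently; the difference between the two cores is not broken down here. Compound 3 and compound 1 give numbers that lie within the usual scatter of each other, while compound 2 lies well below both.

Compound 4 differs from compound 3 by methyl in place of hydrogen on a saturated chain carbon, two bonds along the chain from an oxygen next to a carbonyl group. This is the same kind of change as that from compound 1 to compound 2, but not the same: there the carbon receiving the methyl was bound to two saturated chain carbons, whereas here it sits two bonds along the chain from an oxygen next to a carbonyl group, so that the change reads ethyl to propyl. The earlier step of a number 44 percentage points lower from compound 1 to compound 2 (beyond the scatter) therefore offers only a loose guide. A closer hint comes from the measured compounds themselves, since compound 1 already carries the propyl chain and gives 45%, while compound 3 carries the ethyl chain and gives 53%, two numbers within the scatter of each other on cores that differ. Compound 4 is therefore expected to give about 45% in this assay, likely between 22% and 65%. The step this estimate means is a number 8 percentage points lower from compound 3 to compound 4 (within the scatter), expected to be far smaller than the earlier one.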

Compound 4, a percentage reported as inhibition, at one concentration (the size of the read-out at that concentration, not a potency): 1%
Compound 4: the middle estimate sits 44 percentage points above what was measured, outside the stated range (below it).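

In this assay, methyl in place of hydrogen on a saturated chain carbon, two bonds along the chain from an oxygen next to a carbonyl group, brought a number 52 percentage points lower from compound 3 to compound 4 (beyond the scatter) and so removed nearly all of the inhibition seen for compound 3 at the one concentration tested. These pairs do not show why the numbers fall, and with one pair on each core they cannot show that the result would hold on any further core; the methyl also enters at a different carbon in each pair, since in the earlier pair that carbon is bound to two saturated chain carbons. Even so, a small extension of the chain has cost about the same on both cores, and the size of the fall carried over from one core to the other: the same change on two cores in this assay, a number 44 percentage points lower (beyond the scatter) from compound 1 to compound 2 and a number 52 percentage points lower (beyond the scatter) from compound 3 to compound 4, 8 percentage points apart, within the scatter of two such steps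

The compounds shown leave open how far the chain can be shortened or changed on either core, for instance whether a methyl ester would keep the inhibition, or whether a carboxylic acid or an amide could stand in place of the ester. As far as these compounds go, it also remains open whether a longer chain ending in an amine or a hydroxyl group would bring the inhibition back.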